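The source may report more compounds than this note shows. Statements on the series, on what has been measured and on what is new or still open speak of the compounds shown alone.

Measured compounds:
compound 1 `O=C1Nc2ccccc2C1(c1c[nH]c2ccccc12)c1c[nH]c2ccccc12`, 20400 nM
compound 2 `COc1ccc2[nH]cc(C3(c4c[nH]c5ccc(OC)cc45)C(=O)Nc4ccccc43)c2c1`, 30200 nM
compound 3 `O=C1Nc2ccc(F)cc2C1(c1c[nH]c2ccccc12)c1c[nH]c2ccccc12`, 6600 nM

In a functional assay on HepG2 cells (Homo sapiens) for cytotoxicity, read by MTT assay, with a stated time of 48 h (a lower number here means a stronger inhibitor, a higher number a weaker inhibitor), compound 1 gives 20400 nM and compound 3 gives 6600 nM. The step from compound 1 to compound 3 is a 3.1-fold lower number from compound 1 to compound 3 (0.49 log units; beyond the scatter); the change is fluoro in place of hydrogen on an aromatic carbon. Compound 2 gives 30200 nM; its number is within the scatter of that of compound 1, and the difference between the two cores is not broken down here.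

Compound 4 `COc1ccc2[nH]cc(C3(c4c[nH]c5ccc(OC)cc45)C(=O)Nc4ccc(F)cc43)c2c1` has not been measured in this assay. It differs from compound 2 by fluoro in place of hydrogen on an aromatic carbon, the same change, at the same place, that takes compound 1 to compound 3. Within the data shown here, the only guide is the step from compound 1 to compound 3, a 3.1-fold lower number from compound 1 to compound 3 (0.49 log units; beyond the scatter), seen once. It is therefore expected that compound 4 shows a step of about a 2.7-fold lower number from compound 2 to compound 4 (0.44 log units; beyond the scatter), resting on that single earlier step. Compound 4 is estimated at 11000 nM, most likely between 5000 nM and 25000 nM.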

Compound 4, half-maximal inhibitory concentration: 36600 nM
Compound 4: the middle estimate sits 3.3-fold (0.52 log units) below what was measured; measured number above the stated range.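

In this assay, among these compounds, fluoro in place of hydrogen on an aromatic carbon gives a 1.2-fold higher number from compound 2 to compound 4 (0.08 log units; within the scatter), so on the core of compound 2 the change produces no step that can be told apart from the scatter. Set beside the earlier step, the result shows that the gain seen on the core of compound 1 does not carry over to the core of compound 2: the same change on two cores in this assay, a 3.1-fold lower number (0.49 log units; beyond the scatter) from compound 1 to compound 3 and a 1.2-fold higher number (0.08 log units; within the scatter) from compound 2 to compound 4, 3.7-fold (0.57 log units) apart, beyond the scatter of two such steps It does not show why the two steps part, nor how the change would behave on any third core, as the comparison rests on only two pairs, each seen once.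

The compounds shown leave open whether another group in the same place, such as chloro, a nitrile or an amine, would follow the pattern of either core. They also leave open whether a methyl in place of the amide hydrogen would alter the response to fluoro on either core.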